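The source may hold more compounds than are shown below. What is called first, only, known or untested is meant among the compounds shown, and "the series" means these compounds.

Three compounds have been measured in a functional assay on A549 cells (Homo sapiens) for antiproliferative activity, read by MTT assay, with a stated time of 72 h; on this read-out lower numbers stand for stronger inhibition and higher numbers for weaker inhibition:

Compound 1 `COc1cc(N(C)CCN(C)C)c(NC(=O)c2ccnc(Cl)c2)cc1Nc1nccc(-c2cn(C)c3ccccc23)n1`: 970 nM
Compound 2 `COc1cc(N(C)CCN(C)C)c(NC(=O)c2ccncc2OC)cc1Nc1nccc(-c2cn(C)c3ccccc23)n1`: 2690 nM
Compound 3 `COc1cc(N(C)C)c(NC(=O)c2ccnc(Cl)c2)cc1Nc1nccc(-c2cn(C)c3ccccc23)n1`: 3430 nM

The first pair shows a single change. Compound 2 differs from compound 1 by 3-methoxypyridin-4-yl in place of 2-chloropyridin-4-yl on a carbonyl carbon. That change made a 2.8-fold higher number from compound 1 to compound 2 (0.44 log units; beyond the scatter), a step that goes beyond the scatter of repeated measurements.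

The second pair shows how the two cores differ. Compound 3 differs from compound 1 by hydrogen in place of (dimethylamino)methyl on a saturated chain carbon bound to a nitrogen on an aromatic ring. That change made a 3.5-fold higher number from compound 1 to compound 3 (0.55 log units; beyond the scatter). Among the compounds with values here, compounds 2 and 3 differ in two places at once, so no single step links them, and their two values lie within the scatter of each other.

Compound 4 `COc1cc(N(C)C)c(NC(=O)c2ccncc2OC)cc1Nc1nccc(-c2cn(C)c3ccccc23)n1` has not yet been measured in this assay. It differs from compound 3 by 3-methoxypyridin-4-yl in place of 2-chloropyridin-4-yl on a carbonyl carbon. The place is the same as in the earlier pair, a carbonyl carbon whose other neighbour is an amide-type nitrogen, so this is the same change, now made on the core of compound 3 rather than the core of compound 1.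

Within the data shown here, only one earlier example of this change exists, so the expectation rests on that single step. For compound 4 a step of about a 2.6-fold higher number from compound 3 to compound 4 (0.42 log units; beyond the scatter) is expected, close in size to the earlier one, because compound 1 to compound 2 gave a 2.8-fold higher number from compound 1 to compound 2 (0.44 log units; beyond the scatter). Compound 4 is therefore estimated to give 9000 nM in this assay, with a plausible range from 3500 nM to 25000 nM.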

Compound 4, half-maximal inhibitory concentration: 3030 nM
Beside the measured number, compound 4's estimate is 3.0-fold (0.47 log units) above it, and the stated range ends above it.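

In this assay, placing 3-methoxypyridin-4-yl instead of 2-chloropyridin-4-yl on the carbonyl carbon of the core of compound 3 gave a 1.1-fold lower number from compound 3 to compound 4 (0.05 log units; within the scatter), so the loss seen on the core of compound 1 did not carry over, and the two steps differ: the same change on two cores in this assay, a 2.8-fold higher number (0.44 log units; beyond the scatter) from compound 1 to compound 2 and a 1.1-fold lower number (0.05 log units; within the scatter) from compound 3 to compound 4, 3.1-fold (0.50 log units) apart, beyond the scatter of two such steps. Seen from the other side, hydrogen in place of (dimethylamino)methyl on the chain gave a 1.1-fold higher number from compound 2 to compound 4 (0.05 log units; within the scatter), which also differs from the earlier step for that change: the same change on two cores in this assay, a 3.5-fold higher number (0.55 log units; beyond the scatter) from compound 1 to compound 3 and a 1.1-fold higher number (0.05 log units; within the scatter) from compound 2 to compound 4, 3.1-fold (0.50 log units) apart, beyond the scatter of two such steps. In these four compounds, each change therefore has a size that depends on what stands at the other place, so a step measured on one core is no safe guide to the same step on another; what this does not show is why that happens, or whether the same holds for any other pair of groups.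

Within the data shown here, only two groups on the carbonyl carbon and two chains on the aromatic nitrogen appear here, so this dependence rests on a single set of four compounds. On these data alone, it remains open whether a plain phenyl on the carbonyl carbon, or a longer chain ending in a morpholine on that nitrogen, would show the same dependence.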